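Shifting the amine on a shared core against a rat ion channel

The source may hold more compounds than are shown below. What is called first, only, known or untested is meant among the compounds shown, and "the series" means these compounds.

Of the compounds shown here, three sharing one core have been measured in a functional assay on HEK293 cells for antagonist activity at transient receptor potential cation channel subfamily V member 1 (Rattus norvegicus), read by FLIPR and calcium flux; on this read-out lower numbers stand for stronger inhibition and higher numbers for weaker inhibition. Compound 1 `NC1CCN(c2nc3c(c(Nc4ccc(C(F)(F)F)cc4)n2)CCN(c2ncccc2C(F)(F)F)CC3)C1` carries a 3-aminopyrrolidin-1-yl group on an aromatic carbon of that core. In this assay compound 1 gives only a limit, > 5000 nM, not a number. Compound 2 `CC(C)(C)OC(=O)N1CCCC(Nc2nc3c(c(Nc4ccc(C(F)(F)F)cc4)n2)CCN(c2ncccc2C(F)(F)F)CC3)C1`, in which the same position holds a carbamate-protected piperidinyl amine, gives 239 nM in this assay. Compound 3 `CN(c1nc2c(c(Nc3ccc(C(F)(F)F)cc3)n1)CCN(c1ncccc1C(F)(F)F)CC2)C1CCCNC1`, with methyl(piperidin-3-yl)amino at that carbon, gives 1540 nM in this assay. Of the two numbers shown, compound 3 has the highest, and compound 2 sits a good way below it. Going by the values given here, the one measured step, an at least 3.2-fold lower number from compound 1 to compound 3 (0.51 log units; beyond the scatter), shows that exchanging the amine group here can move the read-out beyond the scatter, although only a limit is available for the starting point (the limit of > 5000 nM in this assay, at which 1 of the 3 values shown sits).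

Compound 4 `CN1CCCCC1CNc1nc2c(c(Nc3ccc(C(F)(F)F)cc3)n1)CCN(c1ncccc1C(F)(F)F)CC2` differs from compound 3 in that (((1-methylpiperidin-2-yl)methyl)amino in place of methyl(piperidin-3-yl)amino on an aromatic carbon). Among the compounds with values here, no measured step bears directly on this exchange; the only comparison that changes the amine group, from compound 1 to compound 3, starts from a limit. The shift is therefore expected to be small and its direction uncertain, which is what a 1.2-fold lower number from compound 3 to compound 4 (0.07 log units; within the scatter) means. In this assay compound 4 is estimated to give 1300 nM, with a likely range from 400 nM to 4500 nM.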

Compound 4, half-maximal inhibitory concentration: 2280 nM
Estimate against measurement, compound 4: 1.8-fold (0.24 log units) below; the measured number falls inside the stated range.
By their numbers in this assay, from the lowest: compound 2; then compounds 3 and 4 (each within the scatter of the next). At a limit, above all of these: compound 1.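

In this assay, the step of a 1.5-fold higher number from compound 3 to compound 4 (0.17 log units; within the scatter) lies within the scatter, so at this carbon, between two ring nitrogen atoms, the read-out does not separate ((1-methylpiperidin-2-yl)methyl)amino from methyl(piperidin-3-yl)amino, although each group holds its six-membered non-aromatic ring in a different arrangement. Going by these compounds alone, the step of an at least 2.1-fold lower number from compound 1 to compound 4 (0.34 log units; beyond the scatter) lies beyond the scatter, which gives a second group, after the one in compound 3, that reads lower than 3-aminopyrrolidin-1-yl at this position. Compound 1 gives only a limit, so the true size of both steps that start from it stays unknown: the limit of > 5000 nM in this assay, at which 1 of the 4 values shown sits.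

Compound 2, at 239 nM, carries a carbamate-protected piperidinyl amine, and the compounds shown leave open whether the carbamate or the ring and its linking amine goes with that value, a question that the plain piperidin-3-ylamino group would address directly. Going by these compounds, it is also open how this assay would read with a morpholine or a simple open-chain amine such as dimethylamino at this carbon, since every group here contains a saturated nitrogen ring.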